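From Methyl to Chloro: What to Expect for Compound 4

This account rests on a few compounds, and the source may have more. Where it says the series, first, only, none or still open, it means among the compounds named here.

Of the compounds shown here, three sharing one core have been measured in a functional assay on MCF7 cells (Homo sapiens) for antiproliferative activity, read by MTT assay, with a stated time of 72 h; a lower number here means a stronger inhibitor, a higher number a weaker inhibitor. Compound 1 `COc1ccc(-c2ccc3ncn(-c4cc(OC)c(OC)c(OC)c4)c3c2)cc1` gives 210 nM. Compound 2 `COc1cc(-n2cnc3ccc(-c4cccc([N+](=O)[O-])c4)cc32)cc(OC)c1OC` gives 4560 nM, and compound 3 `COc1cc(-n2cnc3ccc(-c4cccc(C)c4)cc32)cc(OC)c1OC` gives 360 nM. Among these three numbers compound 3 stands second highest: its nearest neighbour is compound 1, with a 1.7-fold higher number from compound 1 to compound 3 (0.23 log units; within the scatter), a gap within the scatter, while compound 2 lies furthest, with a 13-fold lower number from compound 2 to compound 3 (1.10 log units; beyond the scatter).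

Compound 4 `COc1cc(-n2cnc3ccc(-c4cccc(Cl)c4)cc32)cc(OC)c1OC` has not yet been measured. It differs from compound 3 in one place: chloro in place of methyl on an aromatic carbon. The exchange happens on an aromatic carbon of a six-membered aromatic ring of carbon only, meta to a large group.

Within the data shown here, two measured steps bear on this. The step of a 13-fold lower number from compound 2 to compound 3 (1.10 log units; beyond the scatter) shows that exchanging the group at this position can move the number a long way, and it makes compound 2 the weakest of the three. The step of a 1.7-fold higher number from compound 1 to compound 3 (0.23 log units; within the scatter), however, shows that a 3-methylphenyl and a 4-methoxyphenyl land within the scatter of each other. Among the measured compounds shown here, no measured step exchanges methyl for chloro directly, and nothing among the three compounds points to chloro behaving like nitro. For compound 4 the expected step is a 1.1-fold higher number from compound 3 to compound 4 (0.05 log units; within the scatter), within the scatter. Compound 4 is therefore estimated at 400 nM, with a range from 150 nM to 1100 nM.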

Compound 4, half-maximal inhibitory concentration: 3120 nM
For compound 4 the middle estimate is 7.8-fold (0.89 log units) below the measured one; measured number outside the range, above it.
By their numbers in this assay, from the lowest: compounds 1 and 3 (each within the scatter of the next); then compounds 4 and 2 (each within the scatter of the next).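

At this place on the ring, a change of one heavy atom can move the number a long way: in this assay there is an 8.7-fold higher number from compound 3 to compound 4 (0.94 log units; beyond the scatter) when chloro replaces methyl, so the two groups cannot be treated as interchangeable here. Chloro instead sits with nitro, with a 1.5-fold lower number from compound 2 to compound 4 (0.16 log units; within the scatter) when chloro replaces nitro, which means the large gap seen earlier between the nitro and methyl compounds was not something peculiar to nitro. The comparison with the 4-methoxyphenyl compound gives a 15-fold higher number from compound 1 to compound 4 (1.17 log units; beyond the scatter) for the 3-chlorophenyl group, so among the three groups at this place only methyl stays close to that compound, while the nitro and chloro compounds both go against any broader rule that this place tolerates change.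

Going by these compounds, whether an amine, a carboxylic acid or a longer chain such as ethyl at this same place would stay near the methyl compound or fall with the chloro and nitro compounds remains open. Nothing in the available data offers a reason why methyl parts so sharply from chloro here.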